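Aryl swap on the thiazolidine core: dimethylamino for trimethoxy

The source may report more compounds than this note shows. Statements on the series, on what has been measured and on what is new or still open speak of the compounds shown alone.

Two compounds sharing a core with an octadecyl amide chain have been measured. Compound 1 `CCCCCCCCCCCCCCCCCCNC(=O)[C@@H]1CSC(c2cccc(O)c2)N1` gives 1200 nM in a functional assay on PPC-1 cells (Homo sapiens) for antiproliferative activity, read by sulforhodamine B assay; on this read-out higher numbers stand for weaker inhibition and lower numbers for stronger inhibition. Compound 2 `CCCCCCCCCCCCCCCCCCNC(=O)[C@@H]1CSC(c2cc(OC)c(OC)c(OC)c2)N1` gives 480 nM in this assay. Going by the values given here, the only measured step, a 2.5-fold lower number from compound 1 to compound 2 (0.40 log units; beyond the scatter), shows that the aryl group on the saturated ring carbon shifts the read-out by a modest but real amount. Compound 2 thus stands lowest of the two numbers, with compound 1 the nearest at a higher number.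

Compound 3 `CCCCCCCCCCCCCCCCCCNC(=O)[C@@H]1CSC(c2ccc(N(C)C)cc2)N1` is not yet measured. It differs from compound 2 by 4-(dimethylamino)phenyl in place of 3,4,5-trimethoxyphenyl on a saturated ring carbon. Among the compounds with values here, no measured step describes this exact exchange; the single step from compound 1 to compound 2 concerns a different pair of aryl groups, so it only indicates the general size that an aryl swap at this position can produce. On that basis a step of modest size in either direction, or none beyond the scatter, is plausible for this assay. The account expects compound 3 to give roughly 700 nM, within a range from 250 nM to 2000 nM. This corresponds to an expected step of a 1.5-fold higher number from compound 2 to compound 3 (0.16 log units; within the scatter), carrying considerable uncertainty.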

Compound 3, half-maximal inhibitory concentration: 1100 nM
The estimate for compound 3 lay 1.6-fold (0.20 log units) below the measured number; the measured number falls inside the stated range.
By their numbers in this assay, from the lowest: compound 2; then compounds 3 and 1 (each within the scatter of the next).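

In this assay, replacing 3,4,5-trimethoxyphenyl with 4-(dimethylamino)phenyl on the saturated ring carbon gives a 2.3-fold higher number from compound 2 to compound 3 (0.36 log units; beyond the scatter) and so moves the number up, the opposite direction to the earlier step into the trimethoxy group. Compound 2 now stands apart from both other compounds by steps beyond the scatter, so a second, different aryl group confirms that this position responds to the exchange and that, of the three aryl groups shown, 3,4,5-trimethoxyphenyl gives the lowest number. By contrast, a 1.1-fold lower number from compound 1 to compound 3 (0.04 log units; within the scatter) lies within the scatter, so 3-hydroxyphenyl and 4-(dimethylamino)phenyl cannot be told apart on this read-out, and nothing measured here explains why the trimethoxy compound differs from these two.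

The compounds shown leave open how a plain phenyl group or a phenyl ring carrying a single methoxy group would compare at this position, which would help show whether the full set of methoxy groups matters. They also leave open whether the same order of aryl groups would hold with a shorter chain, such as dodecyl, in place of octadecyl on the amide.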